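Nitro to amino on the shared core

The source may hold more compounds than are shown below. What is called first, only, known or untested is meant among the compounds shown, and "the series" means these compounds.

In a functional assay on PC-3 cells (Homo sapiens) for inhibition, with a stated time of 48 h, tested at 50 uM (on this read-out higher numbers stand for more inhibition of growth at the one concentration tested and lower numbers for less inhibition of growth), compound 1 `C=C[C@@](C)(/C=C/c1ccc(OC(=O)CCCCCCC)cc1)CCC=C(C)C` gives 22% and compound 2 `C=C[C@@](C)(/C=C/c1ccc(O)c([N+](=O)[O-])c1)CCC=C(C)C` gives 52% at the single concentration tested. Compound 2 stands highest of the two, with a gap to compound 1 beyond the scatter. Compound 3 `C=C[C@@](C)(/C=C/c1ccc(O)c(N)c1)CCC=C(C)C` has amino in place of nitro on an aromatic carbon, ortho to a hydroxy group (amino in place of nitro on an aromatic carbon). Going by the values given here, no measured pair isolates this change, so the expectation is loose. A small drop in this assay is expected, an estimated a number 7 percentage points lower from compound 2 to compound 3 (within the scatter) that may stay within the scatter. For compound 3 the estimated value is 45% with 22% to 70% as the expected range.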

Compound 3, percent growth inhibition at one concentration: 28%
Estimate against measurement, compound 3: 17 percentage points above; measured number inside the range.
By their numbers in this assay, from the lowest: compounds 1 and 3 (each within the scatter of the next); then compound 2.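

In this assay the group on the aromatic carbon ortho to a hydroxy group counts: amino in place of nitro gives a number 24 percentage points lower from compound 2 to compound 3 (beyond the scatter) as a modest step. Going by these compounds alone, this is the first read of a change at this position alone, since compound 1 and compound 2 differ in more than one place. Nothing measured here bears on the reason for the step.

Open, on these data alone, is whether an acetamide or a nitrile at this position would keep the number of compound 2. Also open, as far as these compounds go, is whether a methoxy in place of the hydroxy group would change the step.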